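The source may hold more compounds than are shown below. What is called first, only, known or untested is meant among the compounds shown, and "the series" means these compounds.

Working notes on a chalcone-type series sharing the methylamino-carbonyl pyridyloxy core seen in compound 1 `CNC(=O)c1cc(Oc2ccc(C(=O)/C=C/c3cc(OC)c(OC)c(OC)c3)cc2)ccn1`. In a functional assay on PC-3 cells (Homo sapiens) for cytotoxicity, read by MTT assay, with a stated time of 72 h (on this read-out lower numbers stand for stronger inhibition and higher numbers for weaker inhibition), compound 1 gives 3150 nM. Compound 2 `CNC(=O)c1cc(Oc2ccc(/C=C/C(=O)c3ccc(C)cc3)cc2)ccn1` has in this assay "not determined" (no result reported). Going by the values given here, compound 3 `CNC(=O)c1cc(Oc2ccc(C(=O)/C=C/c3ccc(Cl)cc3Cl)cc2)ccn1` gives in this assay 9220 nM, the highest of the two numbers so far; the nearest number is that of compound 1, lower by a margin beyond the usual scatter.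

Compound 4 `CNC(=O)c1cc(Oc2ccc(C(=O)/C=C/c3ccc(Cl)c(Cl)c3)cc2)ccn1` differs from compound 3 only by the change (3,4-dichlorophenyl in place of 2,4-dichlorophenyl on a double-bonded chain carbon bound to a double-bonded chain carbon). With no measured step of this kind in the series, only a modest shift is expected in this assay, more likely toward a lower number; the estimated step from compound 3 to compound 4 is a 1.5-fold lower number from compound 3 to compound 4 (0.19 log units; within the scatter). Compound 4 is thus estimated at 6000 nM, within a range of 1500 nM to 25000 nM.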

Compound 4, half-maximal inhibitory concentration: 8260 nM
Estimate against measurement, compound 4: 1.4-fold (0.14 log units) below; the range from low to high includes it.
By their numbers in this assay, from the lowest: compound 1; then compounds 4 and 3 (each within the scatter of the next).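

In this assay, going by these compounds alone, 3,4-dichlorophenyl in place of 2,4-dichlorophenyl on a double-bonded chain carbon bound to a double-bonded chain carbon gives a 1.1-fold lower number from compound 3 to compound 4 (0.05 log units; within the scatter) as the first measured step at this position. Moving one chlorine around this ring therefore leaves the number within the scatter, so the two dichlorophenyl patterns cannot be ranked. Nothing available explains this result.

Still open, going by these compounds, is whether an amine or a carboxylic acid on this ring would shift the number beyond the scatter. A single chlorine at this position also remains untested among the compounds shown.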